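The source may hold more compounds than are shown below. What is called first, only, known or untested is meant among the compounds shown, and "the series" means these compounds.

The series shares the core seen in compound 1 `CC(Sc1nnc(-c2ccncc2)s1)C(=O)NCc1ccccc1Cl`, compound 2 `O=C(CCSc1nnc(-c2ccncc2)s1)Nc1ccccc1` and compound 3 `O=C(CSc1nnc(-c2ccncc2)s1)NCc1ccccc1Cl`, all carrying a thioether link from a pyridyl-bearing ring to an amide. In an ADME assay on HepG2 cells (Homo sapiens) for cytotoxicity, with a stated time of 3 days (on this read-out higher numbers stand for lower toxicity in this test and lower numbers for higher toxicity in this test), compound 1 reaches only the limit of the assay, > 50000 nM. In this assay compound 2 likewise reaches only the limit, > 50000 nM. Going by the values given here, for compound 3 this assay reports "not determined" (no result reported), so no number marks where it stands; the only guide is the limit of > 50000 nM in this assay, at which 2 of the 3 values shown sit. Compound 4 `O=C(CSc1nnc(-c2ccncc2)s1)Nc1ccc(Cl)cc1` differs from compound 3 by 4-chlorophenyl in place of 2-chlorobenzyl on an amide-type nitrogen. Among the compounds with values here, no measured step exists for such a change; no shift beyond the scatter is expected. In this assay compound 4 is therefore expected to give 50000 nM, within 20000 nM to 100000 nM.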

Compound 4, half-maximal cytotoxic concentration: > 50000 nM
Compound 4: no number, only a limit; the forecaster's own chance of this, stated with the estimate: 75%; the middle value sits exactly at the limit.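

In this assay compound 4 gives only a limit, > 50000 nM. With no result reported for compound 3, no new step can be read between compound 3 and compound 4. The compounds shown leave open at what concentration any of them turns cytotoxic.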